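Swapping One Aromatic Group for Another in a Cytotoxicity Series

The source may hold more compounds than are shown below. What is called first, only, known or untested is meant among the compounds shown, and "the series" means these compounds.

Of the compounds shown here, three have so far been measured in an ADME assay on HepG2 cells (Homo sapiens) for cytotoxicity, read by luminescence, CellTiter-Glo and ATP content, with a stated time of 72 h; on this read-out lower numbers stand for an effect already at smaller amounts and higher numbers for an effect only at larger amounts of compound. Compound 1 `CC(C)Cc1ccc2c(NCCCNCc3ccco3)ccnc2c1` gives 16000 nM. Compound 2 `COc1cccc(CNCCCNc2ccnc3cc(Oc4ccc(Cl)cc4)ccc23)c1O` gives 5700 nM, and compound 3 `COc1cccc(CNCCCNc2ccnc3cc(Cc4ccccc4)ccc23)c1O` gives 5720 nM. Among these numbers compound 3 stands second highest of three: its nearest neighbour is compound 2, whose value lies within the scatter of its own, and its furthest is compound 1, whose higher value lies beyond the scatter.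

Compound 4 `COc1cccc(CNCCCNc2ccnc3cc(-c4ccc(C(F)(F)F)cc4)ccc23)c1O` differs from compound 3 in one place: 4-(trifluoromethyl)phenyl in place of benzyl on an aromatic carbon. Among the measured compounds shown here, one measured step bears on this change, because it alters the group at the same place: a 1.0-fold higher number from compound 2 to compound 3 (0.00 log units; within the scatter). That exchange of one aromatic group for another left the number unchanged within the scatter. For the measured compounds named here, with only that single comparison at hand, and a change that again puts one aromatic group in place of another at the same place, the expected step for compound 4 is one of no more than the scatter, in either direction: a 1.0-fold higher number from compound 3 to compound 4 (0.02 log units; within the scatter). Compound 4 is therefore estimated to give 6000 nM in this assay, with a range from 2500 nM to 14000 nM.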

Compound 4, half-maximal effective concentration: 2210 nM
Compound 4: middle estimate off by 2.7-fold (0.43 log units), on the high side, outside the stated range (below it).
By their numbers in this assay, from the lowest: compound 4; then compounds 2 and 3 (each within the scatter of the next); then compound 1.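

In this assay this position proves not to be indifferent to which aromatic group it carries: 4-(trifluoromethyl)phenyl in place of benzyl gives a clear step (a 2.6-fold lower number from compound 3 to compound 4 (0.41 log units; beyond the scatter)), and the same group in place of 4-chlorophenoxy gives a step of the same size (a 2.6-fold lower number from compound 2 to compound 4 (0.41 log units; beyond the scatter)), whereas the earlier exchange of 4-chlorophenoxy for benzyl stayed within the scatter (a 1.0-fold higher number from compound 2 to compound 3 (0.00 log units; within the scatter)). The new group also differs from both earlier ones in two ways at once, since its ring sits directly on the aromatic carbon of the core and it carries a trifluoromethyl group, so these compounds cannot show which of the two differences goes with the lower number. No measurement shown here gives a reason for the step.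

An unsubstituted phenyl group at this place would help separate those two differences, and a 4-chlorophenyl group would show whether the number follows the group on the ring. As far as these compounds go, whether a non-aromatic group here, such as an amine or a carboxylic acid, would move the number further in either direction stays open.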